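Notes on the pyridinyl ether: from compound 2 to compound 3

The compounds below may be only part of what the source reports. "The series", "measured", "known", "first", "only" and "open" are said of these compounds alone.

Measured so far in a physicochemical assay for lipophilicity, read by LC-MS, in phosphate buffer, measured as octanol-water partition, with a stated time of 30 min, at pH 7.4, tested at 200 mM; a lower number here means a more polar compound, a higher number a more lipophilic compound
- compound 1 `Cn1c(COc2cccc(C(=O)O)c2)nc2ccc(Oc3cccc(Cl)n3)cc21` gives 1.2
- compound 2 `Cc1ccc(C)c(Oc2ccc3nc(COc4cccc(C(=O)O)c4)n(C)c3c2)n1` gives 1.4

Among the measured compounds shown here, compound 2 stands within the scatter of compound 1, the only other measured compound, so no order can be read between them. Next comes compound 3 (`Cn1c(COc2cccc(C(=O)O)c2)nc2ccc(Oc3ncc(Cl)cc3Cl)cc21`), which differs from compound 2 as follows: 3,5-dichloropyridin-2-yl in place of 3,6-dimethylpyridin-2-yl on an oxygen on an aromatic ring. In words, this is 3,5-dichloropyridin-2-yl in place of 3,6-dimethylpyridin-2-yl on an oxygen on an aromatic ring.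

For the measured compounds named here, one measured step bears on this, at the same place: a number 0.20 log units higher from compound 1 to compound 2 (within the scatter). Going by the values given here, no measured step covers the entering group itself. On that single step, no change beyond the scatter is expected in this assay. The estimated step is a number 0.10 log units higher from compound 2 to compound 3 (within the scatter). For compound 3 the expected value is 1.5, with an estimated range of 1.1 to 1.9.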

Compound 3, distribution coefficient: 1.9
Compound 3: the middle estimate sits 0.40 log units below what was measured, within the range that was stated.
By their numbers in this assay, from the lowest: compounds 1 and 2 (each within the scatter of the next); then compound 3.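

In this assay the group on this oxygen now shifts the read-out beyond the scatter: 3,5-dichloropyridin-2-yl in place of 3,6-dimethylpyridin-2-yl gives a number 0.50 log units higher from compound 2 to compound 3 (beyond the scatter), and in place of 6-chloropyridin-2-yl it gives a number 0.70 log units higher from compound 1 to compound 3 (beyond the scatter). The earlier pair showed no readable order at this place, whereas compound 3 now stands clear of both other compounds, with the shared core unchanged. Nothing on hand gives a reason for these steps.

The compounds shown leave open how much of either step belongs to each chlorine of 3,5-dichloropyridin-2-yl, as each step changes more than one substituent on the pyridine ring at once. Going by these compounds, it also remains open where an amine or a methoxy group on that ring would fall in this order.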